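A few compounds are considered here, and "the series" means these few. Any claim that something is new, unique, unknown or untested is made for them only; others in the source may bear on it.

Series notes. Compound 1 `Nc1scc(CN2CCN(c3ccncc3)CC2)c1C(=O)c1ccc(Cl)cc1` serves as the reference point. In an assay on CHO cells for displacement of a labelled ligand from adenosine receptor A1 (Homo sapiens), read by scintillation counting, with a stated time of 120 min, tested at 10 uM (on this read-out lower numbers stand for less inhibition and higher numbers for more inhibition at the one concentration tested (going by the name of the read-out)), compound 1 gives 1%. Compound 2 `Nc1scc(CN2CCN(c3c(F)cc(F)cc3F)CC2)c1C(=O)c1ccc(Cl)cc1` differs from it by 2,4,6-trifluorophenyl in place of pyridin-4-yl on an amine nitrogen in a ring; in this assay compound 2 gives 0%, and the step is a number 1 percentage points lower from compound 1 to compound 2 (within the scatter). On the numbers shown compound 1 and compound 2 are indistinguishable, since the gap between them is within the scatter, and neither reading rises appreciably from the baseline.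

Compound 3 `Nc1scc(CN2CCN(c3ccccc3Cl)CC2)c1C(=O)c1ccc(Cl)cc1` is not yet measured; it differs from compound 1 by 2-chlorophenyl in place of pyridin-4-yl on an amine nitrogen in a ring. Among the compounds with values here, the one measured step that bears on this change is the exchange of the same pyridin-4-yl for another aromatic ring on the amine nitrogen in a ring, which gave a number 1 percentage points lower from compound 1 to compound 2 (within the scatter) and stayed within the scatter. For compound 3 the step of no change at the digits printed from compound 1 to compound 3 (within the scatter) is therefore expected to stay within the scatter as well, with no movement beyond it in either direction. The estimate for compound 3 in this assay is 1%, with a range from -8% to 10%.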

Compound 3, a percentage reported as inhibition, at one concentration (the size of the read-out at that concentration, not a potency): 2%
The estimate for compound 3 lay 1 percentage points below the measured number; the range from low to high includes it.
By their numbers in this assay, from the lowest: compounds 2, 1 and 3 (each within the scatter of the next).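

Working from this assay, the position on the amine nitrogen in a ring now carries a third aromatic group, 2-chlorophenyl, and the step from the pyridine-bearing reference is a number 1 percentage points higher from compound 1 to compound 3 (within the scatter). Against the fluorinated analogue, the step is a number 2 percentage points higher from compound 2 to compound 3 (within the scatter), so a single chlorine on a carbon-only ring reads the same as both the three fluorines of 2,4,6-trifluorophenyl and the ring nitrogen of pyridin-4-yl. The change therefore extends the flat picture from one exchange to three aromatic groups at this place, none separable from the others and all close to the baseline at the one concentration tested, and nothing at hand accounts for these readings.

On these data alone, with all three readings near the baseline, it remains open whether any group on this nitrogen can raise the inhibition, for instance a saturated cyclohexyl ring, a short alkyl chain, or a phenyl ring bearing a methoxy group or a carboxylic acid. As far as these compounds go, it also remains open whether other parts of the shared core, rather than this position, govern the reading.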